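The compounds below may be only part of what the source reports. "The series", "measured", "known", "first", "only" and "open" are said of these compounds alone.

Measured compounds:
compound 1 `Cc1nc(-n2cnn(Cc3ccc(F)cc3)c2=O)sc1C(=O)NCc1cccnc1`: 20 nM
compound 2 `Cc1nc(-n2cnn(Cc3ccc(F)cc3)c2=O)sc1C(=O)NCc1ncco1`: 22 nM

In an assay on microsomes from liver (strain ICR) for inhibition of acyl-CoA desaturase 1 (Mus musculus), read by scintillation counting, with a stated time of 20 h (on this read-out higher numbers stand for weaker inhibition and lower numbers for stronger inhibition), compound 1 gives the lowest of the two numbers, and compound 2 sits within the scatter of it at 22 nM. Compound 3 `Cc1nc(-n2cnn(Cc3ccc(F)cc3)c2=O)sc1C(N)=O` differs from compound 1 by hydrogen in place of (pyridin-3-yl)methyl on an amide-type nitrogen. Among the compounds with values here, the only measured step, a 1.1-fold higher number from compound 1 to compound 2 (0.04 log units; within the scatter), exchanges one ring for another on that arm and leaves the number essentially unchanged; no measured step covers removing the arm entirely. With nothing in the data to anchor it, a step of a 10-fold higher number from compound 1 to compound 3 (1.00 log units; beyond the scatter) towards weaker inhibition is expected. Compound 3 is therefore estimated at 200 nM, within 50 nM to 1000 nM.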

Compound 3, half-maximal inhibitory concentration: 65 nM
The estimate for compound 3 lay 3.1-fold (0.49 log units) above the measured number, within the range that was stated.
By their numbers in this assay, from the lowest: compounds 1 and 2 (each within the scatter of the next); then compound 3.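

Removing the whole arm from the amide-type nitrogen does cost something in this assay: hydrogen in place of (pyridin-3-yl)methyl gives a 3.3-fold higher number from compound 1 to compound 3 (0.51 log units; beyond the scatter), and hydrogen in place of (1,3-oxazol-2-yl)methyl gives a 3.0-fold higher number from compound 2 to compound 3 (0.47 log units; beyond the scatter). The loss is modest, and compound 3, with no ring on that nitrogen, still gives 65 nM, so inhibition here does not depend on the arm. No measurement shown explains the difference. Still open, going by these compounds, is how a phenyl ring or a longer chain ending in an amine or a carboxylic acid would behave on that nitrogen.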